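A few compounds are considered here, and "the series" means these few. Any claim that something is new, unique, unknown or untested is made for them only; others in the source may bear on it.

Measured so far in an ADME assay on A549 cells (Homo sapiens) for cytotoxicity, read by MTT assay, with a stated time of 24 h, tested at 200 ug/mL; a higher number here means a weaker effect of the compound at the concentration tested, a lower number a stronger effect:
compound 1 `CO[C@H]1O[C@@H]([C@@H](N=[N+]=[N-])C(=O)OCc2ccccc2)[C@@H](OCc2ccccc2)[C@@]2(OCc3ccccc3)[C@@H](OCc3ccccc3)CO[C@@H]12` gives 64.3%
compound 2 `CC(=O)Nc1nc(Cl)c2c(ncn2[C@@H]2O[C@@H]([C@H](N=[N+]=[N-])C(=O)OCc3ccccc3)[C@@H](OCc3ccccc3)[C@@]3(OCc4ccccc4)[C@@H](OCc4ccccc4)CO[C@@H]23)n1` gives 51.3%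

Compound 2 holds the lower of the two numbers; compound 1 stands higher by a gap beyond the usual scatter. Among the compounds with values here, no single-point step between compound 1 and compound 2 is available, as the two differ in more than one place.

Compound 3 `COC(=O)[C@@H](N=[N+]=[N-])[C@@H]1O[C@@H](n2cnc3nc(NC(C)=O)nc(Cl)c32)[C@@H]2OC[C@H](OCc3ccccc3)[C@]2(OCc2ccccc2)[C@@H]1OCc1ccccc1` differs from compound 2 by hydrogen in place of phenyl on a saturated chain carbon bound to an oxygen next to a carbonyl group. Within the data shown here, no measured step of this kind exists. The step of a number 4.7 percentage points higher from compound 2 to compound 3 (within the scatter) is estimated to stay within the scatter, if anything slightly upward. Compound 3 is expected to give 56%, with a range from 42% to 70%.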

Compound 3, a percentage reported as activity, at one concentration (the size of the read-out at that concentration, not a potency): 19.5%
Compound 3: the middle estimate sits 36.5 percentage points above what was measured; measured number below the stated range.
By their numbers in this assay, from the lowest: compound 3; then compound 2; then compound 1.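

In this assay, within the data shown here, benzyloxycarbonyl to methoxycarbonyl gives a number 31.8 percentage points lower from compound 2 to compound 3 (beyond the scatter), the first single-place step, which shows that this ester position is not indifferent to substitution. The shorter methoxycarbonyl group goes with the stronger effect at the tested concentration, though this rests on one pair only. Nothing available explains the step.

From the compounds shown here alone, it remains open whether the result follows from losing the phenyl or is specific to the methyl ester. An ethyl ester or a free carboxylic acid at this position would help separate the two.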